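Small-group swaps on an aromatic carbon of the shared core

The source may hold more compounds than are shown below. What is called first, only, known or untested is meant among the compounds shown, and "the series" means these compounds.

Measured so far:
compound 1 `O=C1O/C(=C\Cn2ccc(=O)[nH]c2=O)C(OCc2ccccc2)=C1OCc1ccccc1` — 50000 nM
compound 2 `O=C1O/C(=C\Cn2cc(C(F)(F)F)c(=O)[nH]c2=O)C(OCc2ccccc2)=C1OCc1ccccc1` — 20000 nM
compound 3 `O=C1O/C(=C\Cn2cc(I)c(=O)[nH]c2=O)C(OCc2ccccc2)=C1OCc1ccccc1` — 30000 nM

All three were run in a functional assay on HeLa cells (Homo sapiens) for inhibition; on this read-out lower numbers stand for stronger inhibition and higher numbers for weaker inhibition. Compound 3 stands second highest of the three numbers; its nearest step is a 1.5-fold higher number from compound 2 to compound 3 (0.18 log units; within the scatter) and its furthest is a 1.7-fold lower number from compound 1 to compound 3 (0.22 log units; within the scatter), both within the scatter, so the three compounds cannot be ordered against each other on these data. For the measured compounds named here, the only step that reaches beyond the scatter is a 2.5-fold lower number from compound 1 to compound 2 (0.40 log units; beyond the scatter), and it is modest.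

Compound 4 `O=C1O/C(=C\Cn2cc(F)c(=O)[nH]c2=O)C(OCc2ccccc2)=C1OCc1ccccc1` differs from compound 3 by fluoro in place of iodo on an aromatic carbon. Going by the values given here, the steps that bear on this place are the hydrogen-to-iodo step a 1.7-fold lower number from compound 1 to compound 3 (0.22 log units; within the scatter) and the trifluoromethyl-to-iodo step a 1.5-fold higher number from compound 2 to compound 3 (0.18 log units; within the scatter), both within the scatter; taken with the modest step of a 2.5-fold lower number from compound 1 to compound 2 (0.40 log units; beyond the scatter), the numbers at this carbon move little whichever small group sits there. A step of no more than the scatter, in either direction, is therefore expected for a 1.2-fold higher number from compound 3 to compound 4 (0.07 log units; within the scatter). Compound 4 is estimated at 35000 nM, with an expected range of 15000 nM to 80000 nM.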

Compound 4, half-maximal inhibitory concentration: 40000 nM
Compound 4: the middle estimate sits 1.1-fold (0.06 log units) below what was measured; the measured number falls inside the stated range.
By their numbers in this assay, from the lowest: compounds 2, 3, 4 and 1 (each within the scatter of the next, the first and the last beyond it).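

In this assay fluoro is a fourth small group at this carbon, and the step of a 1.3-fold higher number from compound 3 to compound 4 (0.12 log units; within the scatter) joins the step of a 2.0-fold higher number from compound 2 to compound 4 (0.30 log units; within the scatter) and the step of a 1.3-fold lower number from compound 1 to compound 4 (0.10 log units; within the scatter) in lying within the scatter. Fluoro therefore cannot be told apart from iodo, trifluoromethyl or hydrogen here, and compound 4 stands within the scatter of both compound 1 and compound 2, the only pair separated beyond it. No supporting data bear on these small differences.

As far as these compounds go, whether an amine, a carboxylic acid or a longer chain at this carbon would shift the number beyond the scatter stays open. Also open, from the compounds shown here alone, is whether changes elsewhere on the shared core would have a larger effect in this assay than these small-group swaps.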